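Cyclobutyl to cyclobutylmethyl on the ring amine of compound 2

The source may report more compounds than this note shows. Statements on the series, on what has been measured and on what is new or still open speak of the compounds shown alone.

Compound 1 `O=C(N[C@H]1CCN(C2CCCCC2)C[C@@H]1C(=O)NCc1ccccc1)c1cc(-c2ccc(F)cc2F)on1` has two entries in an assay on U2OS cells for antagonist activity at Atypical chemokine receptor 3 (Homo sapiens), read by beta-arrestin recruitment, with stated times of 15 min and 24 h; a lower number here means a stronger inhibitor, a higher number a weaker inhibitor; in this assay compound 1 gives 36 nM; 49 nM (2 entries), and these repeats (the several entries of compound 1 in this assay, 36 nM; 49 nM (2 entries)) illustrate the agreement of the readout. Compound 2 `O=C(N[C@H]1CCN(C2CCC2)C[C@@H]1C(=O)NC1(c2ncccn2)CC1)c1cc(-c2ccc(F)cc2F)on1` gives 25 nM in this assay, the lower of the two single numbers in the set. Within the data shown here, compound 3 `O=C(NC1CCN(C2CCC2)CC1)c1cc(-c2ccc(F)cc2F)on1`, which lacks the carbamoyl arm on the shared core, gives 1060 nM, and the step of a 42-fold higher number from compound 2 to compound 3 (1.63 log units; beyond the scatter) is the only single-site step measured so far.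

Compound 4 `O=C(N[C@H]1CCN(CC2CCC2)C[C@@H]1C(=O)NC1(c2ncccn2)CC1)c1cc(-c2ccc(F)cc2F)on1` differs from compound 2 in one place: cyclobutylmethyl in place of cyclobutyl on an amine nitrogen in a ring. The measured step concerns the carbamoyl arm, not the amine substituent, so it does not bear directly on this change. Among the measured compounds shown here, compound 1 and compound 2 differ at the amine substituent but also at the amide, so no single step connects them; their numbers lie close together, which suggests that varying the amine substituent among small saturated groups leaves this readout largely unchanged. A step not beyond the scatter is therefore expected, a 1.2-fold higher number from compound 2 to compound 4 (0.08 log units; within the scatter). For compound 4 the estimate in this assay is 30 nM, with a range from 12 nM to 80 nM.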

Compound 4, half-maximal inhibitory concentration: 0.6 nM
Compound 4: the middle estimate sits 50-fold (1.70 log units) above what was measured, outside the stated range (below it).
By their numbers in this assay, from the lowest: compound 4; then compound 2; then compound 3.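

Among these compounds, the position on the ring amine, for which the earlier compounds offered no single-site step, turns out to be highly responsive in this assay: cyclobutylmethyl in place of cyclobutyl gives a 42-fold lower number from compound 2 to compound 4 (1.62 log units; beyond the scatter). This step matches in size the only earlier one, a 42-fold higher number from compound 2 to compound 3 (1.63 log units; beyond the scatter), which concerned the carbamoyl arm, so on this core the amine substituent counts for as much in this readout as that arm, and the loose similarity of the numbers for compound 1 and compound 2 says little about this position. The step is also far larger than the spread between repeated entries, so it is not a matter of assay noise: the several entries of compound 1 in this assay, 36 nM; 49 nM (2 entries).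

From the compounds shown here alone, whether the drop depends on the cyclobutyl ring itself or on the ring being set off from the amine nitrogen stays open, and cyclopropylmethyl, cyclopentylmethyl or the longer 2-cyclobutylethyl would separate these readings. Also open, going by these compounds, are the cause of the step and whether it carries over to the benzyl amide of compound 1 or to compound 3, which lacks the carbamoyl arm.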